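Swapping 4-Chlorophenyl for Hydrogen: Expected Tolerance in Liver Cells

This account rests on a few compounds, and the source may have more. Where it says the series, first, only, none or still open, it means among the compounds named here.

Compound 1 `Cc1cc(=O)oc2cc(OCc3cn(-c4ccc(Cl)cc4)nn3)ccc12` was tested in an ADME assay on Huh-7 cells (Homo sapiens) for cytotoxicity, read by MTT assay, with a stated time of 72 h; a higher number here means that more compound is tolerated, a lower number that less compound is tolerated. In this assay compound 1 gives > 100 ug/mL, which is a limit of the assay rather than a measured number. A second compound with the same core, compound 2 `COc1ccc(-n2cc(COc3ccc4c(C)cc(=O)oc4c3)nn2)c(OC)c1`, was also examined; in this assay compound 2 gives > 100 ug/mL, again a limit. Compound 1 therefore stands at the limit of > 100 ug/mL in this assay, at which 2 of the 2 values shown sit, so no ranking between the two is possible.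

Compound 3 `Cc1cc(=O)oc2cc(OCc3c[nH]nn3)ccc12` has not yet been measured. It differs from compound 1 by hydrogen in place of 4-chlorophenyl on an aromatic nitrogen. Among the measured compounds shown here, no measured pair shows this particular change, so its effect on tolerated concentration is unknown. Both compounds whose values are known sit at the same limit, and the change is a removal of a single group, so the expected step in this assay is none beyond the scatter. Compound 3 is therefore expected to give about 120 ug/mL, most likely in the range from 60 ug/mL to 300 ug/mL, and the step from compound 1 to compound 3 is estimated as a step that the limit leaves unreadable from compound 1 to compound 3.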

Compound 3, half-maximal cytotoxic concentration: > 100 ug/mL
Compound 3: a limit, no number (the forecaster's own chance of this, stated with the estimate: 85%); the middle value does not contradict the limit.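

No step can be read from compound 1 to compound 3, because each result is a limit of the assay rather than a number: the limit of > 100 ug/mL in this assay, at which 3 of the 3 values shown sit.

The compounds shown leave open at what concentration any of them stops being tolerated in this assay, and whether hydrogen in place of 4-chlorophenyl changes that concentration at all.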